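Swapping the lactam of compound 3 for an anilide

This account rests on a few compounds, and the source may have more. Where it says the series, first, only, none or still open, it means among the compounds named here.

Of the compounds shown here, three sharing one core have been measured in a functional assay on A549 cells (Homo sapiens) for inhibition, read by sulforhodamine B assay, with a stated time of 72 h; on this read-out lower numbers stand for stronger inhibition and higher numbers for weaker inhibition. Compound 1 `COc1ccc(CNC(=O)c2c(N)sc(-c3ccc(Cl)cc3)c2-c2ccc(Cl)cc2)cc1` gives 18200 nM. Compound 2 `Nc1sc(-c2ccc(Cl)cc2)c(-c2ccc(Cl)cc2)c1C(=O)N1CCC(=O)CC1=O` gives 4090 nM, and compound 3 `Nc1sc(-c2ccc(Cl)cc2)c(-c2ccc(Cl)cc2)c1C(=O)N1CCCCC1=O` gives 1820 nM. Compound 3 therefore holds the lowest number of the three: the step of a 10-fold lower number from compound 1 to compound 3 (1.00 log units; beyond the scatter) and the step of a 2.2-fold lower number from compound 2 to compound 3 (0.35 log units; beyond the scatter) both run in its favour, so it stands as the strongest inhibitor among the measured set.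

Compound 4 `Nc1sc(-c2ccc(Cl)cc2)c(-c2ccc(Cl)cc2)c1C(=O)Nc1ccccc1` differs from compound 3 in one place: anilino in place of 2-oxopiperidin-1-yl on a carbonyl carbon. The anilino group, like the (4-methoxybenzyl)amino group of compound 1, brings a hydrogen-bond donor to the carbonyl carbon, whereas the 2-oxopiperidin-1-yl group of compound 3 brings none. The step most relevant to this exchange is therefore a 10-fold lower number from compound 1 to compound 3 (1.00 log units; beyond the scatter), which went the other way, from such a donor-bearing group to the lactam. The step of a 2.2-fold lower number from compound 2 to compound 3 (0.35 log units; beyond the scatter) adds that the lactam was also favoured over its dioxo relative. Moving from compound 3 to compound 4 is thus expected to raise the number in this assay, with a step estimated as a 4.4-fold higher number from compound 3 to compound 4 (0.64 log units; beyond the scatter). For compound 4 the expected value is 8000 nM, with a range from 2500 nM to 30000 nM.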

Compound 4, half-maximal inhibitory concentration: 25000 nM
Compound 4: the middle estimate sits 3.1-fold (0.49 log units) below what was measured; the range from low to high includes it.
By their numbers in this assay, from the lowest: compound 3; then compound 2; then compounds 1 and 4 (each within the scatter of the next).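

In this assay, the anilino group gives a 14-fold higher number from compound 3 to compound 4 (1.14 log units; beyond the scatter), the largest step seen so far on this carbonyl carbon, so the position clearly responds to what is attached there. The anilino group also trails the ring with two carbonyls, with a 6.1-fold higher number from compound 2 to compound 4 (0.79 log units; beyond the scatter), which means that both ring groups, in compound 2 and compound 3, give lower numbers than this simple aromatic amide. The third comparison, a 1.4-fold higher number from compound 1 to compound 4 (0.14 log units; within the scatter), cannot separate phenyl from 4-methoxybenzyl on the amide-type nitrogen, so compound 1 and compound 4, which both keep the amide hydrogen, sit together at the weak end of this small set, whether the nitrogen carries an aromatic ring directly or a benzyl group.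

No measurement is available to explain these differences. As far as these compounds go, it remains open whether the amide hydrogen, the ring carbonyl or the shape of the ring drives the gap: an N-methylanilide would replace only the amide hydrogen of compound 4, and a piperidin-1-yl amide would remove only the ring carbonyl of compound 3.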